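The compounds below may be only part of what the source reports. "The series", "measured", "known", "first", "only" and "open" are said of these compounds alone.

Compound 1 `CNC(=O)c1cc(C(=O)NC2CC2)cn(Cc2ccc(OC)cc2)c1=O` and compound 2 `CNC(=O)c1cc(C(=O)NCCC2CCOCC2)cn(Cc2ccccc2)c1=O` were both read in a physicochemical assay for solubility; on this read-out higher numbers stand for higher solubility and lower numbers for lower solubility. In this assay compound 1 gives >= 143 ug/mL, which is a limit of the assay and not a number. In the same assay compound 2 gives >= 127 ug/mL, and this too is only a limit, so compound 2 stands without an exact value. Compound 3 `CNC(=O)c1cc(C(=O)NC(C)C)cn(Cc2ccccc2)c1=O` has isopropyl in place of 2-(oxan-4-yl)ethyl on an amide-type nitrogen. Within the data shown here, no step between measured compounds is available to size this change. With compound 2 at >= 127 ug/mL, a limit, no step beyond the scatter is expected in this assay, in either direction. The expected change is a step that the limit leaves unreadable from compound 2 to compound 3. For compound 3 the estimated solubility is 140 ug/mL, with an expected range from 70 ug/mL to 165 ug/mL.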

Compound 3, solubility: >= 136 ug/mL
Compound 3 ended at the assay's limit; the forecaster's own chance of this, stated with the estimate: 65%; the middle value lies beyond the limit too.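

In this assay, compound 2 and compound 3 both end at limits of the assay, so isopropyl in place of 2-(oxan-4-yl)ethyl gives no readable step between them. The compounds shown leave open the exact solubility of compound 1, compound 2 and compound 3.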